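N-alkyl extension on the spiro lactam of the chromone series

The source may report more compounds than this note shows. Statements on the series, on what has been measured and on what is new or still open speak of the compounds shown alone.

Compound 1 `Cc1ccc2c(c1)C1(C(=O)N2C)C(C#N)=C(N)Oc2cc3oc(-c4ccccc4)cc(=O)c3c(O)c21` gives 5870 nM in a functional assay on K562 cells (Homo sapiens) for antiproliferative activity, read by MTT assay, with a stated time of 48 h (a higher number here means a weaker inhibitor, a lower number a stronger inhibitor), the highest of the three numbers in hand. Compound 2 `CN1C(=O)C2(C(C#N)=C(N)Oc3cc4oc(-c5ccccc5)cc(=O)c4c(O)c32)c2cc(Cl)ccc21` gives 4340 nM and compound 3 `CN1C(=O)C2(C(C#N)=C(N)Oc3cc4oc(-c5ccccc5)cc(=O)c4c(O)c32)c2cc(Br)ccc21` gives 4100 nM; the moves a 1.4-fold lower number from compound 1 to compound 2 (0.13 log units; within the scatter), a 1.4-fold lower number from compound 1 to compound 3 (0.16 log units; within the scatter) and a 1.1-fold lower number from compound 2 to compound 3 (0.02 log units; within the scatter) all stay within the scatter, so the three compounds cannot be ordered. Compound 4 `CCN1C(=O)C2(C(C#N)=C(N)Oc3cc4oc(-c5ccccc5)cc(=O)c4c(O)c32)c2cc(C)ccc21` differs from compound 1 by methyl in place of hydrogen on a saturated chain carbon bound to an amide-type nitrogen in a ring. For the measured compounds named here, no measured step touches this position; the three known steps vary only the aromatic substituent and were all within the scatter. With nothing bearing on the change, no step beyond the scatter is expected in this assay . Compound 4 is therefore estimated at 6000 nM, range 2500 nM to 14000 nM, which would mean an expected 1.0-fold higher number from compound 1 to compound 4 (0.01 log units; within the scatter).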

Compound 4, half-maximal inhibitory concentration: > 50000 nM
Compound 4 gave a limit, no number; the forecaster's own chance of this, stated with the estimate: 5%; middle value at least 8.3-fold (0.92 log units) from the limit.
By their numbers in this assay, from the lowest: compounds 3, 2 and 1 (each within the scatter of the next). At a limit, above all of these: compound 4.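

Compound 4 reads only as a limit, not a number, in this assay: the limit of > 50000 nM in this assay, at which 1 of the 4 values shown sits. Methyl to ethyl at this position gives an at least 8.5-fold higher number from compound 1 to compound 4 (0.93 log units; beyond the scatter), the only step beyond the scatter so far; the aromatic substituent swaps all stayed within it. This position therefore responds to a single added carbon in a way the aromatic carbon did not.

Only methyl and ethyl are shown here, so it remains open how activity depends on the group at this position; the amide hydrogen or a propyl chain would bear on that. As far as these compounds go, whether ethyl has the same effect alongside chloro or bromo also remains open.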